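A few compounds are considered here, and "the series" means these few. Any claim that something is new, unique, unknown or untested is made for them only; others in the source may bear on it.

Measured compounds:
Compound 1, `Cc1ccc(Oc2ccc3nc(COc4cccc(C(=O)O)c4)n(C)c3n2)cc1` — 33 ug/mL
Compound 2, `Cn1c(COc2cccc(C(=O)O)c2)nc2ccc(Oc3ccc4c(c3)OCC4)nc21` — 17 ug/mL
Compound 3, `Cc1ccc(Oc2cc3c(cn2)nc(COc2cccc(C(=O)O)c2)n3C)cc1` — 360 ug/mL

These three compounds were measured in a physicochemical assay for solubility, read by HPLC, measured as thermodynamic solubility, with a stated time of 4 h, at pH 6.8; on this read-out higher numbers stand for higher solubility and lower numbers for lower solubility. Compound 1 and compound 2 share a core and differ by one change, (a group of 9 heavy atoms (8 carbon, 1 oxygen; one five-membered non-aromatic ring with 1 hetero atom, one six-membered aromatic ring of carbon only) in place of a group of 7 heavy atoms (7 carbon; one six-membered aromatic ring of carbon only), on an oxygen on an aromatic ring); that change gave a 1.9-fold lower number from compound 1 to compound 2 (0.29 log units; within the scatter). Compound 3 has the same atoms as compound 1 joined differently; the difference between the two cores is not broken down here. Compound 3 stands highest of the three in this assay, beyond the scatter from both compound 1 and compound 2.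

Compound 4, `Cn1c(COc2cccc(C(=O)O)c2)nc2cnc(Oc3ccc4c(c3)OCC4)cc21`, has not yet been measured. It is made from compound 3 by the same change, (a group of 9 heavy atoms (8 carbon, 1 oxygen; one five-membered non-aromatic ring with 1 hetero atom, one six-membered aromatic ring of carbon only) in place of a group of 7 heavy atoms (7 carbon; one six-membered aromatic ring of carbon only), on an oxygen on an aromatic ring), at the same kind of position. Going by the values given here, the one earlier instance of this change, from compound 1 to compound 2, moved the number only within the scatter, so compound 4 is expected to stay close to compound 3, with an estimated step of a 1.9-fold lower number from compound 3 to compound 4 (0.28 log units; within the scatter). Because the earlier step was a 1.9-fold lower number from compound 1 to compound 2 (0.29 log units; within the scatter), the estimate for compound 4 in this assay is 190 ug/mL, between 80 ug/mL and 420 ug/mL.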

Compound 4, solubility: 79 ug/mL
Beside the measured number, compound 4's estimate is 2.4-fold (0.38 log units) above it; measured number below the stated range.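

In this assay, replacing 4-methylphenyl with the group of 9 heavy atoms, on an oxygen on an aromatic ring, gave a 4.6-fold lower number from compound 3 to compound 4 (0.66 log units; beyond the scatter), while on the other core the same change gave a 1.9-fold lower number from compound 1 to compound 2 (0.29 log units; within the scatter). Only the first of these steps is beyond the scatter, so the change did not carry over as a step that could be read as negligible on every core, and one matched pair per core is too little to show how much the core governs the size of the step. Nothing measured here explains why the two steps read differently.

Going by these compounds, it remains open how a different group on that same oxygen, such as an amine or a longer chain, would behave on each of the two cores. On these data alone, it is also open whether a further core would give a step beyond the scatter, as this new pair did, or one within it, as the earlier pair did.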